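A Fluorinated Swap at the Meta Position of the Aryl Group

This account rests on a few compounds, and the source may have more. Where it says the series, first, only, none or still open, it means among the compounds named here.

This study looks at a small set of compounds sharing one core and tested in a functional assay on HCT-15 cells (Homo sapiens) for cytotoxicity, read by MTT assay, with a stated time of 2 days; a higher number here means a weaker inhibitor, a lower number a stronger inhibitor. Compound 1, `Cc1ccc2nc(-c3cccc(OC(F)(F)F)c3)[nH]c(=O)c2c1`, carries a trifluoromethoxy group on its pendant aromatic ring. In this assay compound 1 gives > 50000 nM, which is a limit of the assay rather than a measured number, so only an upper bound on its potency is known; it stands at the limit of > 50000 nM in this assay, at which 2 of the 3 values shown sit. Compound 2, `Cc1ccc2nc(-c3ccccc3C(F)(F)F)[nH]c(=O)c2c1`, also reaches only a limit, giving > 50000 nM in this assay. Among the measured compounds shown here, compound 3, `CN(C)c1ccc2nc(-c3cccc4ccccc34)[nH]c(=O)c2c1`, is the one member with a real number, giving 460 nM in this assay.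

The compound still to be tested is compound 4, `Cc1ccc2nc(-c3cccc(C(F)(F)F)c3)[nH]c(=O)c2c1`. It differs from compound 1 in one place: trifluoromethyl in place of trifluoromethoxy on an aromatic carbon. The change keeps the same ring and the same point of attachment, and only the oxygen that links the fluorinated carbon to the ring is removed.

For the measured compounds named here, since compound 1 sits at the limit, no measured step is available to anchor the size of this change. The step of a number no higher from compound 1 to compound 4 (the limit leaves the size open) is expected to be small, with no shift beyond the usual scatter. Compound 4 is therefore estimated to give 50000 nM, within a range from 15000 nM to 150000 nM.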

Compound 4, half-maximal inhibitory concentration: > 50000 nM
Compound 4 gave a limit, no number; the forecaster's own chance of this, stated with the estimate: 75%; the middle value lies on the limit itself.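

Compound 1 and compound 4 both end at a limit of the assay rather than at a number, so no step between them can be read in this assay: the limit of > 50000 nM in this assay, at which 3 of the 4 values shown sit.

The compounds shown leave open whether trifluoromethyl in place of trifluoromethoxy on an aromatic carbon changes potency at all.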